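Swapping a Sulfur Linker for a Double Bond

The source may report more compounds than this note shows. Statements on the series, on what has been measured and on what is new or still open speak of the compounds shown alone.

Three compounds share one core, seen in compound 1 `CC(C)Cn1c(=O)n(C)c(=O)c2[nH]c(=O)c(Cc3cccc4ccccc34)nc21`, compound 2 `CC(C)Cn1c(=O)n(C)c(=O)c2nc(SCCCCO)c(Cc3cccc4ccccc34)nc21` and compound 3 `CC(C)Cn1c(=O)n(C)c(=O)c2nc(-c3[nH]nnc3CCCO)c(Cc3cccc4ccccc34)nc21`. Among the measured compounds shown here, in an assay on MCF7 cells for inhibition of Monocarboxylate transporter 1 (Homo sapiens), read by scintillation counting, with a stated time of 10 min (on this read-out higher numbers stand for weaker inhibition and lower numbers for stronger inhibition), compound 2 gives 669 nM, and this is the only number so far. In this assay compound 1 gives "not determined" (no result reported). In this assay compound 3 gives "not determined" (no result reported). For the measured compounds named here, with no second number reported, no step between measured compounds can be drawn. Compound 4 `CC(C)Cn1c(=O)n(C)c(=O)c2nc(/C=C\CCCO)c(Cc3cccc4ccccc34)nc21` has not yet been measured. It differs from compound 2 in one place: 5-hydroxypent-1-en-1-yl in place of (4-hydroxybutyl)sulfanyl on an aromatic carbon. The chain that leaves and the chain that enters match in the number of heavy atoms counted, and each keeps a hydrogen-bond donor; sulfur leaves and a double bond enters. Going by the values given here, with a single number in hand and no measured step to guide it, the expectation is that compound 4 stays close to compound 2, with the step of a 1.0-fold higher number from compound 2 to compound 4 (0.02 log units; within the scatter) expected to lie within the usual scatter. Compound 4 is estimated at 700 nM, with a range from 250 nM to 2000 nM.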

Compound 4, half-maximal inhibitory concentration: 116 nM
Estimate against measurement, compound 4: 6.0-fold (0.78 log units) above; the measured number lies below the stated range.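

This result shows that the aromatic carbon carrying the chain is sensitive to the chain's makeup, not just to its presence: in this assay, replacing (4-hydroxybutyl)sulfanyl with 5-hydroxypent-1-en-1-yl gives a 5.8-fold lower number from compound 2 to compound 4 (0.76 log units; beyond the scatter). The two chains match in heavy atoms and in hydrogen-bond donors, so neither of those counts can account for the change, while sulfur, a double bond and one hydrogen-bond acceptor do differ between them. Nothing measured here explains why the number falls.

The compounds shown leave open whether the double bond's arrival or sulfur's departure matters more, a question that a saturated 5-hydroxypentyl chain could help separate. Also open, going by these compounds, is whether the hydroxyl itself matters, which an amine or a carboxylic acid in its place would test.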